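Swapping the ring on the chain carbon of compound 2

The source may report more compounds than this note shows. Statements on the series, on what has been measured and on what is new or still open speak of the compounds shown alone.

Measured so far in an assay on CHO cells for displacement of a labelled ligand from prostaglandin E2 receptor EP3 subtype (Homo sapiens), read by radioligand binding; on this read-out higher numbers stand for weaker inhibition and lower numbers for stronger inhibition:
- compound 1, `CCn1ncc2c(F)cc(-c3ccc(C(CC)(CC)c4nnc(C)[nH]4)c(=O)[nH]3)cc21`, gives 34 nM
- compound 2, `CC(C)C(c1ccc(-c2ccc3cccc(F)c3c2)[nH]c1=O)N1CCN/C1=N\C#N`, gives 23 nM
- compound 3, `CC(C)C(O)(C(=O)O)c1ccc(-c2ccc3ccccc3c2)[nH]c1=O`, gives 544 nM

Compound 2 has the lowest of the three numbers in this assay. Its number and that of compound 1 lie within the usual scatter of each other, so the two cannot be told apart; compound 3 stands far beyond the scatter with a much higher number, that is, clearly weaker inhibition.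

Compound 4, `CC(C)C(Cc1noc(=O)[nH]1)c1ccc(-c2ccc3cccc(F)c3c2)[nH]c1=O`, differs from compound 2 in one place: a group of 7 heavy atoms (3 carbon, 2 nitrogen, 2 oxygen; one five-membered aromatic ring with 3 hetero atoms) in place of a group of 8 heavy atoms (4 carbon, 4 nitrogen; one five-membered non-aromatic ring with 2 hetero atoms), on a saturated chain carbon bound to an aromatic carbon and a saturated chain carbon. Among the compounds with values here, no step between measured compounds shows what such a change does, so the expectation rests on compound 2 alone. A modest move toward a higher number in this assay seems plausible, but one that may well stay within the scatter. The expected step from compound 2 to compound 4 is a 2.0-fold higher number from compound 2 to compound 4 (0.29 log units; within the scatter). Compound 4 is estimated at 45 nM, with a range from 12 nM to 200 nM.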

Compound 4, inhibition constant: 34 nM
Estimate against measurement, compound 4: 1.3-fold (0.12 log units) above; measured number inside the range.
By their numbers in this assay, from the lowest: compounds 2, 1 and 4 (each within the scatter of the next); then compound 3.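

On the saturated chain carbon bound to an aromatic carbon and a saturated chain carbon, replacing the five-membered non-aromatic ring with 2 hetero atoms by a five-membered aromatic ring with 3 hetero atoms gives a 1.5-fold higher number from compound 2 to compound 4 (0.17 log units; within the scatter) in this assay, so compound 2 and compound 4 cannot be told apart. Within the data shown here, this is the first direct sign that this position accepts two quite different ring groups, one with a triple bond outside its ring and one containing oxygen, without a measurable change in this assay. Nothing available here explains why the two groups read alike.

From the compounds shown here alone, whether this holds for other groups on the same carbon remains open, for example a tetrazole ring, a simple amine or a plain methyl group. The compounds shown also leave open whether a longer chain between this carbon and the ring would be accepted equally well.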